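A few compounds are considered here, and "the series" means these few. Any claim that something is new, unique, unknown or untested is made for them only; others in the source may bear on it.

Among the measured compounds shown here, compound 2 `NCc1cccc(CN(C[C@H]2Cc3ccccc3CN2)[C@H]2CCCc3cccnc32)c1` gives 292 nM in a functional assay on cells for antagonist activity at C-X-C chemokine receptor type 4 (Homo sapiens), read by fluorescence and calcium flux, with stated times of 25 min and 90 s (a lower number here means a stronger inhibitor, a higher number a weaker inhibitor), the highest of the two numbers measured so far; compound 1 `c1ccc2c(c1)CN[C@@H](CN(CCCCNCC1CCNCC1)[C@H]1CCCc3cccnc31)C2` gives 36.5 nM. For the measured compounds named here, the one step available is an 8.0-fold higher number from compound 1 to compound 2 (0.90 log units; beyond the scatter). Compound 3 `C(=C/CN(C[C@H]1Cc2ccccc2CN1)[C@H]1CCCc2cccnc21)\CNCC1CCOCC1` carries a group of 11 heavy atoms (9 carbon, 1 nitrogen, 1 oxygen; one six-membered non-aromatic ring with 1 hetero atom) in place of a group of 8 heavy atoms (7 carbon, 1 nitrogen; one six-membered aromatic ring of carbon only), on a saturated chain carbon bound to an amine nitrogen. This partly reverses the earlier change, since the entering group again has a six-membered non-aromatic ring with one hetero atom on a longer chain, though with oxygen in place of the second nitrogen of compound 1. The step is therefore expected to be a modestly lower number, a 3.2-fold lower number from compound 2 to compound 3 (0.51 log units; beyond the scatter), short of a full return to compound 1. Compound 3 is estimated at 90 nM, within 30 nM to 300 nM.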

Compound 3, half-maximal inhibitory concentration: 24.2 nM
Beside the measured number, compound 3's estimate is 3.7-fold (0.57 log units) above it; the whole stated range lies above it.
By their numbers in this assay, from the lowest: compounds 3 and 1 (each within the scatter of the next); then compound 2.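

At this saturated chain carbon bound to an amine nitrogen, the entering group with its six-membered non-aromatic ring with 1 hetero atom gives a 12-fold lower number from compound 2 to compound 3 (1.08 log units; beyond the scatter) in this assay and so recovers what the 3-(aminomethyl)phenyl group lacked. Oxygen in that ring, with a double bond in the chain, gives a 1.5-fold lower number from compound 1 to compound 3 (0.18 log units; within the scatter) and shows that a second nitrogen in the ring is not needed for a number of this size. Open, on these data alone, are the separate share of the double bond and the reading of a longer chain or a carboxylic acid on this carbon. Nothing measured here explains either step.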